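Aryl swap on the amide ring: compound 4 ahead of measurement

The compounds below may be only part of what the source reports. "The series", "measured", "known", "first", "only" and "open" are said of these compounds alone.

Three compounds on the shared core have been run in a functional assay on HT-29 cells (Homo sapiens) for cytotoxicity, read by MTT assay, with a stated time of 72 h; on this read-out higher numbers stand for weaker inhibition and lower numbers for stronger inhibition. Compound 1 `COc1cc2c(Oc3ccc(NC(=O)c4cc(-c5ccccc5F)ccn4)cc3F)ccnc2cc1OCCCN1CCCCC1` gives 320 nM. Compound 2 `COc1ccc(-c2ccnc(C(=O)Nc3ccc(Oc4ccnc5cc(OCCCN6CCCCC6)c(OC)cc45)c(F)c3)c2)cc1` gives 690 nM. Compound 3 `COc1cc2c(Oc3ccc(NC(=O)c4cc(-c5ccccc5C)ccn4)cc3F)ccnc2cc1OCCCN1CCN(C)CC1` gives 180 nM, the lowest of the three numbers; its gap to compound 1 lies within the scatter, its gap to compound 2 beyond it, so compound 3 cannot be called the most potent outright.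

For the measured compounds named here, the only single-point step among the measured compounds is a 2.2-fold higher number from compound 1 to compound 2 (0.33 log units; beyond the scatter), which replaces an aryl of the 2-fluorophenyl type with one of the 4-methoxyphenyl type.

Compound 4 `COc1cc2c(Oc3ccc(NC(=O)c4cc(-c5ccc(C(F)(F)F)cc5)ccn4)cc3F)ccnc2cc1OCCCN1CCN(C)CC1` is not yet measured. It differs from compound 3 by 4-(trifluoromethyl)phenyl in place of 2-methylphenyl on an aromatic carbon, sitting meta to a large group and opposite the ring nitrogen. The step from compound 1 to compound 2 is the one that bears on it, since it too moves the substituent from the 2-fluorophenyl arrangement to the 4-methoxyphenyl arrangement, and it gave a modest weakening. Going by the values given here, a step of similar size and direction is therefore expected here, a 1.9-fold higher number from compound 3 to compound 4 (0.29 log units; within the scatter), with wide uncertainty because only that one step exists and the entering trifluoromethyl has no precedent in the set. Compound 4 is estimated at 350 nM, in the range 150 nM to 900 nM.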

Compound 4, half-maximal inhibitory concentration: 200 nM
The estimate for compound 4 lay 1.8-fold (0.24 log units) above the measured number; the measured number falls inside the stated range.
By their numbers in this assay, from the lowest: compounds 3, 4 and 1 (each within the scatter of the next); then compound 2.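

In this assay, the step at the aromatic carbon opposite the ring nitrogen, a 1.1-fold higher number from compound 3 to compound 4 (0.05 log units; within the scatter), lies within the scatter, so 4-(trifluoromethyl)phenyl and 2-methylphenyl cannot be told apart here, even though the entering group has 10 heavy atoms against 7. The earlier step at this carbon, a 2.2-fold higher number from compound 1 to compound 2 (0.33 log units; beyond the scatter), lay beyond the scatter, so an aryl change here does not always move the number beyond the scatter, though the two pairs differ elsewhere on the shared core and in the aryl groups exchanged, and the two steps cannot be read as one effect. No measurement at hand explains either step.

The compounds shown leave open how far this carbon tolerates groups other than substituted phenyl, and how an aryl bearing an amine, a carboxylic acid or a nitrile would read in this assay. They also leave open whether 4-(trifluoromethyl)phenyl gives a similar number on the side chain of compound 1, and whether 2-methylphenyl and 2-fluorophenyl can be told apart on one unchanged background.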